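Methyl in place of bromo: from compound 2 to compound 3

The compounds below may be only part of what the source reports. "The series", "measured", "known", "first", "only" and "open" are said of these compounds alone.

Two compounds carry a value in a functional assay (Mus musculus, strain Balb/c) for inhibition, read by ELISA, with a stated time of 72 h; a lower number here means a stronger inhibitor, a higher number a weaker inhibitor. Compound 1 `O/N=C(\C=C\c1ccc(Cl)cc1)c1ccc(Cl)cc1` gives 9150 nM in this assay. Compound 2 `O/N=C(\C=C\c1ccc(Cl)c(Cl)c1)c1ccc(Br)cc1` is known in this assay only by a limit: compound 2 gives < 5000 nM, which is a limit of the assay and not a number. Where compound 2 stands is told by the limit of < 5000 nM in this assay, at which 1 of the 2 values shown sits. Going by the values given here, no step between the measured compounds is given, so the two values show only that compound 1 has a measured number while compound 2 sits at the limit.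

Compound 3 `Cc1ccc(C(/C=C/c2ccc(Cl)c(Cl)c2)=N/O)cc1` is not yet measured. It differs from compound 2 in one place: methyl in place of bromo on an aromatic carbon. Among the compounds with values here, no measured step of this kind is available, so its size is uncertain; in what is counted the change is small, and no move beyond the scatter is expected in this assay. Compound 3 is estimated at 4000 nM in this assay, with a range from 1000 nM to 15000 nM. The expected step is a step that the limit leaves unreadable from compound 2 to compound 3.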

Compound 3, half-maximal inhibitory concentration: 6340 nM
Beside the measured number, compound 3's estimate is 1.6-fold (0.20 log units) below it, within the range that was stated.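

In this assay, methyl in place of bromo on an aromatic carbon, para to a large group, reads as an at least 1.2-fold higher number from compound 2 to compound 3 (0.10 log units; that floor lies within the scatter). Compound 2 is known only by < 5000 nM, which is a limit of the assay and not a number. Compound 3 gives 6340 nM, so this position now carries a measured number with methyl on the shared core. The true size of the change stays unread, and nothing beyond the scatter can be claimed for it, because the step rests on this limit: the limit of < 5000 nM in this assay, at which 1 of the 3 values shown sits.

Still open, going by these compounds, is whether another kind of group at this position, such as a methoxy group, an amine or a carboxylic acid, would shift the number in this assay beyond the scatter. Also open, on these data alone, is whether methyl in place of bromo would give a step of similar size on a core carrying different groups on its other aromatic ring, and whether such a step would then be readable between two measured numbers.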